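Shifting the Methyl Group on the Aryl Urea

A few compounds are considered here, and "the series" means these few. Any claim that something is new, unique, unknown or untested is made for them only; others in the source may bear on it.

Three compounds share one urea-linked cyclohexane core. Compound 1 `O=C(Nc1cccc(C(F)(F)F)c1)N[C@H]1CC[C@@H](Oc2ccc(F)cc2)CC1` gives 2600 nM in a functional assay on CRL2813 cells (Homo sapiens) for cytotoxicity, read by sulforhodamine B assay, with a stated time of 5 days; a lower number here means a stronger inhibitor, a higher number a weaker inhibitor. Compound 2 `Cc1ccc(NC(=O)N[C@H]2CC[C@H](Oc3ccc(F)cc3)CC2)cc1` reaches only the assay limit of > 20000 nM in this assay. Compound 3 `O=C(Nc1cccc(C(F)(F)F)c1)N[C@H]1CC[C@H](O)CC1` likewise stops at the limit of > 20000 nM in this assay. Compound 2 therefore stands at the weak end of what has been seen, sitting at the limit of > 20000 nM in this assay, at which 2 of the 3 values shown sit.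

The next compound, compound 4 `Cc1cccc(NC(=O)N[C@H]2CC[C@H](Oc3ccc(F)cc3)CC2)c1`, differs from compound 2 by one change: 3-methylphenyl in place of 4-methylphenyl on an amide-type nitrogen. Such a small rearrangement is expected to move potency by at most a modest amount, most likely toward a slightly stronger value. Compound 4 is expected to give about 15000 nM in this assay, with a plausible range from 4000 nM to 40000 nM, a step of an at least 1.3-fold lower number from compound 2 to compound 4 (0.12 log units; that floor lies within the scatter) from compound 2.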

Compound 4, half-maximal inhibitory concentration: 14400 nM
Compound 4: the middle estimate sits 1.0-fold (0.02 log units) above what was measured; measured number inside the range.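

Swapping 4-methylphenyl for 3-methylphenyl on the amide-type nitrogen gives an at least 1.3-fold lower number from compound 2 to compound 4 (0.14 log units; that floor lies within the scatter). Of this pair, only compound 4 gives a measured number in this assay, so this position can yield a readable value, though the printed step does not clear the usual scatter. Compound 2 remains a limit, so the true size of the step is unknown: the limit of > 20000 nM in this assay, at which 2 of the 4 values shown sit.

The compounds shown leave open what a chlorine atom, a methoxy group or a carboxylic acid would do in place of the methyl group on this ring.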